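A Chlorine Shift on a Nearly Unmeasured Series

The compounds below may be only part of what the source reports. "The series", "measured", "known", "first", "only" and "open" are said of these compounds alone.

- compound 1 `COc1ccc(C2=NN(c3ccccc3Cl)C(c3cccc(Cl)c3)C2)cc1`: 1500 nM
- compound 2 `COc1cccc(C2=NN(c3ccc(Cl)cc3)C(c3ccc(Cl)cc3)C2)c1`: "not determined" (no result reported)
- compound 3 `COc1cccc(C2=NN(c3ccccc3Cl)C(c3cccc(Cl)c3)C2)c1`: "not determined" (no result reported)

In a functional assay on HCT-116 cells (Homo sapiens) for cytotoxicity, read by a luciferase reporter and CellTiter-Glo, with a stated time of 72 h (a lower number here means a stronger inhibitor, a higher number a weaker inhibitor), compound 3 has no single number to stand on, only the entry "not determined" (no result reported). Going by the values given here, the sole number in this small set belongs to compound 1, at 1500 nM.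

The next compound to be tested is compound 4 `COc1cccc(C2=NN(c3ccc(Cl)cc3)C(c3cccc(Cl)c3)C2)c1`. It has 4-chlorophenyl in place of 2-chlorophenyl on an amine nitrogen in a ring. The two compounds have the same atoms, joined differently, so this is a change of arrangement and not of composition.

Compound 2 also carries 4-chlorophenyl on an amine nitrogen in a ring, but its entry is "not determined" (no result reported), so it gives no guide to this change. Among the compounds with values here, no pair of measured compounds shows how large such a step can be. In this assay the expectation is therefore no step beyond the usual scatter, and no direction can be favoured. The best anchor is compound 1 at 1500 nM, and the uncertainty around it is wide.

For compound 4 the expected value is 1500 nM, with an estimated range from 350 nM to 6500 nM.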

Compound 4, half-maximal inhibitory concentration: 18500 nM
Compound 4: middle estimate off by 12-fold (1.09 log units), on the low side, and the stated range ends below it.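

In this assay compound 4 gives 18500 nM but compound 3, which carries 2-chlorophenyl where compound 4 carries 4-chlorophenyl, stands only as "not determined", so no step can be read from this pair. As far as these compounds go, how moving that chlorine alters potency stays open. No supporting evidence bears on this result.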